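Aryl swap on the aromatic nitrogen of compound 2

The compounds below may be only part of what the source reports. "The series", "measured", "known", "first", "only" and "open" are said of these compounds alone.

Two compounds of the shared core have been run in an ADME assay on HUVEC cells (Homo sapiens) for antiproliferative activity, read by MTT assay, with a stated time of 48 h; on this read-out lower numbers stand for stronger inhibition and higher numbers for weaker inhibition. Compound 1 `N#CC1=C(N)Oc2c(c3nc4ccccc4nc3c3ccccc23)C12C(=O)N(Cc1cnnn1-c1ccc([N+](=O)[O-])cc1)c1ccccc12` returns only a limit in this assay, > 50000 nM, which is the point where (the limit of > 50000 nM in this assay, at which 1 of the 2 values shown sits). Compound 2 `N#CC1=C(N)Oc2c(N)cc3nc4ccccc4nc3c2C12C(=O)N(Cc1cnnn1-c1ccccc1Br)c1ccccc12` gives 34200 nM in this assay. Within the data shown here, compound 2 holds the only numeric value in the set, and no measured step between compounds is available. Compound 3 `N#CC1=C(N)Oc2c(N)cc3nc4ccccc4nc3c2C12C(=O)N(Cc1cnnn1-c1c(F)cccc1F)c1ccccc12` carries 2,6-difluorophenyl in place of 2-bromophenyl on an aromatic nitrogen. Nothing measured in this assay speaks to such a swap of one aromatic ring for another; the expectation is a step of no more than the usual scatter, in no set direction. Compound 3 is therefore estimated at 35000 nM in this assay, within 15000 nM to 80000 nM. The step of a 1.0-fold higher number from compound 2 to compound 3 (0.01 log units; within the scatter) is the expected change, with a real chance that this assay again returns only a limit.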

Compound 3, half-maximal inhibitory concentration: > 50000 nM
Compound 3 was reported as a limit; the forecaster's own chance of this, stated with the estimate: 35%; middle value at least 1.4-fold (0.15 log units) away from the limit.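

In this assay, among these compounds, the exchange of 2-bromophenyl for 2,6-difluorophenyl on the aromatic nitrogen gives an at least 1.4-fold higher number from compound 2 to compound 3 (0.16 log units; that floor lies within the scatter) as the first step that can be read. Compound 3 is reported only as a limit, so this step is a floor and not a size, and with that floor inside the scatter the position is shown neither to respond to this swap nor to be indifferent to it. The upper end of the read-out now holds most of the set: the limit of > 50000 nM in this assay, at which 2 of the 3 values shown sit.

Among the compounds shown here, how far the number can fall with another group at this position remains open, as compound 2 is the only compound with a numeric value. A phenyl ring carrying an amine or a carboxylic acid in place of the halogens would show whether this position can move the read-out at all.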